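This account rests on a few compounds, and the source may have more. Where it says the series, first, only, none or still open, it means among the compounds named here.

Measured compounds in a functional assay on MV4-11 cells (Homo sapiens) for antiproliferative activity, with a stated time of 6 days, tested at 6.25 uM; on this read-out lower numbers stand for a weaker effect and higher numbers for a stronger effect at the one concentration tested:

compound 1, `CNC(=O)N1CCCc2ccc(NC(=O)c3ccc(-c4ccccc4)cc3)cc21`, 74.3%
compound 2, `CNC(=O)N1CCCc2ccc(NC(=O)c3ccc(-c4ccn(C(C)=O)n4)cc3)cc21`, 91.4%
compound 3, `CNC(=O)N1CCCc2ccc(NC(=O)c3ccc(-c4ccn(S(C)(=O)=O)n4)cc3)cc21`, 57.2%

Compound 3 is the lowest of the three numbers; its nearest neighbour is compound 1, with the step of a number 17.1 percentage points lower from compound 1 to compound 3 (beyond the scatter), and the furthest is compound 2, with the step of a number 34.2 percentage points lower from compound 2 to compound 3 (beyond the scatter).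

The next compound, compound 4, `CNC(=O)N1CCCc2ccc(NC(=O)c3ccc(-c4cn[nH]c4)cc3)cc21`, is not yet measured. Its change from compound 3 is 1H-pyrazol-4-yl in place of 1-(methylsulfonyl)-1H-pyrazol-3-yl on an aromatic carbon.

Going by the values given here, two measured steps bear on this. The step of a number 34.2 percentage points lower from compound 2 to compound 3 (beyond the scatter) shows that the methylsulfonyl on the aromatic nitrogen goes with the weakest number in the set, while the step of a number 17.1 percentage points lower from compound 1 to compound 3 (beyond the scatter) shows that even the plain phenyl of compound 1 sits clearly above compound 3. Compound 4 removes the methylsulfonyl altogether and keeps only a five-membered ring with 2 hetero atoms and 1 hydrogen-bond donor. Among the compounds with values here, no measured step shows a pyrazole without a group on its nitrogen, so the size of the gain is uncertain, but a step upward beyond the scatter is expected.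

For compound 4 the estimate is 76%, within 55% to 92%, which means an expected step of a number 18.8 percentage points higher from compound 3 to compound 4 (beyond the scatter).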

Compound 4, a percentage reported as inhibition, at one concentration (the size of the read-out at that concentration, not a potency): 98.3%
Compound 4: middle estimate off by 22.3 percentage points, on the low side; the measured number lies above the stated range.
By their numbers in this assay, from the lowest: compound 3; then compound 1; then compounds 2 and 4 (each within the scatter of the next).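

In this assay the aromatic carbon para to a large group accepts a pyrazole with a hydrogen-bond donor and no group on its nitrogen: 1H-pyrazol-4-yl in place of 1-(methylsulfonyl)-1H-pyrazol-3-yl gives a number 41.1 percentage points higher from compound 3 to compound 4 (beyond the scatter) and shows that the smaller ring, at 5 heavy atoms against 9, loses nothing at this position. The same ring also improves on the plain phenyl, with a number 24 percentage points higher from compound 1 to compound 4 (beyond the scatter) in this series, whereas the comparison with the acetylated pyrazole gives a number 6.9 percentage points higher from compound 2 to compound 4 (within the scatter) and so does not separate these two groups, which means that an acetyl group on the ring nitrogen is not needed for a high number. Nothing on hand accounts for these steps.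

The change from compound 3 joins two edits, the loss of methylsulfonyl and the move from the 3-yl to the 4-yl attachment, and their shares stay unresolved without 1H-pyrazol-3-yl or 1-(methylsulfonyl)-1H-pyrazol-4-yl at this position. Also open, on these data alone, is how a small alkyl group such as methyl, or a hydroxyethyl chain, on the pyrazole nitrogen would read in this single-concentration test.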